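Swapping 4-ethoxyphenyl for 3-methoxyphenyl on the amide nitrogen

This account rests on a few compounds, and the source may have more. Where it says the series, first, only, none or still open, it means among the compounds named here.

Three measured compounds share one core and differ only in the group on the amide nitrogen. In a functional assay on Huh-7 cells (Homo sapiens) for inhibition, read by MTT assay, with a stated time of 48 h (a lower number here means a stronger inhibitor, a higher number a weaker inhibitor), compound 1 `COc1ccc2c(=O)c(/C=C/C(=O)NCc3cccc(F)c3)coc2c1` gives 10100 nM, compound 2 `COc1ccc2c(=O)c(/C=C/C(=O)NCc3ccccc3)coc2c1` gives 13600 nM, and compound 3 `CCOc1ccc(NC(=O)/C=C/c2coc3cc(OC)ccc3c2=O)cc1` gives 3230 nM, the lowest of the three: a 3.1-fold lower number from compound 1 to compound 3 (0.50 log units; beyond the scatter) and a 4.2-fold lower number from compound 2 to compound 3 (0.62 log units; beyond the scatter). Compound 4 `COc1cccc(NC(=O)/C=C/c2coc3cc(OC)ccc3c2=O)c1` differs from compound 3 in one place: 3-methoxyphenyl in place of 4-ethoxyphenyl on an amide-type nitrogen. For the measured compounds named here, no measured step reshapes an aryl group on that nitrogen; the closest guide is a 1.3-fold higher number from compound 1 to compound 2 (0.13 log units; within the scatter), a small change on a ring that stayed within the scatter. The step is therefore expected to be small, perhaps a slightly higher number, a 1.4-fold higher number from compound 3 to compound 4 (0.14 log units; within the scatter). Compound 4 is estimated at 4500 nM, with a range from 1800 nM to 12000 nM.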

Compound 4, half-maximal inhibitory concentration: 11100 nM
Compound 4: middle estimate off by 2.5-fold (0.39 log units), on the low side, within the range that was stated.
By their numbers in this assay, from the lowest: compound 3; then compounds 1, 4 and 2 (each within the scatter of the next).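

Swapping one aryl group for another on the amide-type nitrogen is not always a small change: 3-methoxyphenyl in place of 4-ethoxyphenyl gives a 3.4-fold higher number from compound 3 to compound 4 (0.54 log units; beyond the scatter) and removes the edge held by compound 3. Compound 4 instead sits level with the two benzyl amides, with a 1.2-fold lower number from compound 2 to compound 4 (0.09 log units; within the scatter) and a 1.1-fold higher number from compound 1 to compound 4 (0.04 log units; within the scatter), so having an aryl group directly on that nitrogen does not by itself give a lower number. Nothing available explains the loss.

As far as these compounds go, the swap alters both the ether chain and its place on the ring, and which of these matters stays open. So does what an amine or a carboxylic acid on that ring would give.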